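From an isobutylamine chain to a carbamoylpiperidine ring

The source may hold more compounds than are shown below. What is called first, only, known or untested is meant among the compounds shown, and "the series" means these compounds.

Compound 1, `CC1=NN(C(=O)c2ccc(C)cc2)C(c2ccccc2O)C1`, gives 26300 nM in a functional assay on MGC-803 cells (Homo sapiens) for cytotoxicity, read by MTT assay, with a stated time of 48 h; a lower number here means a stronger inhibitor, a higher number a weaker inhibitor.
Compound 2, `CC(=O)Oc1ccccc1C1CC(C)=NN1C(=O)CN1CCC(C(C)=O)CC1`, gives 4120 nM in this assay.
Compound 3, `CC(C)CNCC(=O)N1N=C(c2cc3ccccc3oc2=O)CC1c1ccccc1`, gives 29700 nM in this assay.

Among these three, compound 3 stands at the highest number. The nearest is compound 1, whose number lies within the usual scatter of that of compound 3, so the two cannot be ordered. For the measured compounds named here, compound 2 is the furthest, with a number that lies beyond the scatter below compound 3; since compound 2 differs from compound 3 in many places, its value shows only that a lower number is reachable.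

Compound 4, `NC(=O)C1CCN(CC(=O)N2N=C(c3cc4ccccc4oc3=O)CC2c2ccccc2)CC1`, has not yet been measured. It differs from compound 3 in one place: 4-carbamoylpiperidin-1-yl in place of isobutylamino on a saturated chain carbon bound to a carbonyl carbon. Going by the values given here, no two measured compounds differ in a single place, so no measured step shows what such a change does. Compound 2 also contains a piperidine, but it differs from compound 3 in too many places for a step to be read from it. For this assay a modest step towards a lower number is expected, possibly no larger than the scatter, namely a 2.0-fold lower number from compound 3 to compound 4 (0.30 log units; within the scatter). Compound 4 is estimated at 15000 nM, with a range from 5000 nM to 45000 nM.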

Compound 4, half-maximal inhibitory concentration: 21500 nM
Beside the measured number, compound 4's estimate is 1.4-fold (0.16 log units) below it, and the stated range covers the measured number.
By their numbers in this assay, from the lowest: compound 2; then compounds 4, 1 and 3 (each within the scatter of the next).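

For the compounds shown here, this is the first step in the set that changes a single place: in this assay, putting 4-carbamoylpiperidin-1-yl in place of isobutylamino on a saturated chain carbon bound to a carbonyl carbon gives a 1.4-fold lower number from compound 3 to compound 4 (0.14 log units; within the scatter). The new group brings a six-membered non-aromatic ring and more heavy atoms, yet a step of this size means that compound 3 and compound 4 cannot be ordered, so this read-out does not tell the open chain and the ring-bearing group apart at this position. Nothing measured here offers an explanation for that result.

From the compounds shown here alone, it remains open whether any change at this position can produce a step beyond the scatter, and whether the ring and the carbamoyl group on it each matter: a plain piperidin-1-yl group, a morpholin-4-yl ring or a longer amine chain would each probe a different part of the change. Compound 2 differs from compound 3 and compound 4 in too many places to settle either question.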